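The compounds below may be only part of what the source reports. "The series", "measured", "known", "first", "only" and "open" are said of these compounds alone.

Of the compounds shown here, two have been measured in a functional assay on MGC-803 cells (Homo sapiens) for antiproliferative activity, read by CCK-8 assay, with a stated time of 72 h, tested at 2 uM; a lower number here means a weaker effect, a higher number a stronger effect of the compound at the concentration tested. Compound 1, `CC1CCN(C(=S)SCc2ccc(C(=O)Nc3ccccc3N)cc2)CC1`, gives 28.1%. Compound 2, `Nc1ccccc1NC(=O)c1ccc(CSC(=S)N2CCN(Cc3ccncc3)CC2)cc1`, gives 18.4%. On paper compound 2 holds the lower of the two numbers, but its distance from compound 1 lies within the usual scatter of this measurement, so the two are effectively alike. Compound 3, `Nc1ccccc1NC(=O)c1ccc(CSC(=S)N2CCN(Cc3cccnc3)CC2)cc1`, shares the core of compound 2 and differs from it in a single place: pyridin-3-yl in place of pyridin-4-yl on a saturated chain carbon bound to an amine nitrogen in a ring. For the measured compounds named here, no pair of measured compounds differs in only one place, so there is nothing here to show how large such a change usually turns out. Exchanging pyridin-4-yl for pyridin-3-yl is expected to produce a step of a number 1.6 percentage points higher from compound 2 to compound 3 (within the scatter) that stays within the scatter. Compound 3 is therefore estimated at 20%, with a range from 6% to 34%.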

Compound 3, a percentage reported as inhibition, at one concentration (the size of the read-out at that concentration, not a potency): 37.7%
For compound 3 the middle estimate is 17.7 percentage points below the measured one; the whole stated range lies below it.
By their numbers in this assay, from the lowest: compounds 2, 1 and 3 (each within the scatter of the next, the first and the last beyond it).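

Exchanging pyridin-4-yl for pyridin-3-yl on a saturated chain carbon bound to an amine nitrogen in a ring gives, in this assay, a number 19.3 percentage points higher from compound 2 to compound 3 (beyond the scatter). For the compounds shown here, the two compounds hold the same atoms, joined differently, so at this position the arrangement of the ring alone can shift the inhibition beyond the usual scatter, which no earlier pair could show. No supporting data are available to explain why the pyridin-3-yl compound gives the higher number.

On these data alone, whether pyridin-2-yl or a plain phenyl ring in the same place would give a higher or lower number remains open. As far as these compounds go, with only a single concentration, it is also open whether this step reflects a real difference in potency.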